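A few compounds are considered here, and "the series" means these few. Any claim that something is new, unique, unknown or untested is made for them only; others in the source may bear on it.

Compound 1, with the structure `OC[C@H]1O[C@@H](n2cnc3c(NCc4ccc(Br)cc4)ncnc32)[C@H](O)[C@@H]1O`, is tested in a functional assay on K562 cells (Homo sapiens) for antiproliferative activity, with a stated time of 72 h (a lower number here means a stronger inhibitor, a higher number a weaker inhibitor), and gives 68200 nM. Among the measured compounds shown here, this is the only actual number in the set: the second compound's result is a limit of the assay rather than a measurement. Compound 2, the structure `COc1ccc(CNc2ncnc3c2ncn3[C@@H]2O[C@H](CO)[C@@H](O)[C@H]2O)c(OC)c1`, reaches only > 166000 nM in this assay, which is a limit. The measured step is an at least 2.4-fold higher number from compound 1 to compound 2 (0.38 log units; beyond the scatter), and it is bounded by the limit of > 166000 nM in this assay, at which 1 of the 2 values shown sits.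

Compound 3, the structure `Cc1ccc(O)c(CNc2ncnc3c2ncn3[C@@H]2O[C@H](CO)[C@@H](O)[C@H]2O)c1`, has not yet been measured. It differs from compound 1 in one place: 2-hydroxy-5-methylphenyl in place of 4-bromophenyl on a saturated chain carbon bound to a nitrogen on an aromatic ring. For the measured compounds named here, the one measured step that bears on this change is the one from compound 1 to compound 2, where a substituted phenyl took the place of the 4-bromophenyl and the result fell to the limit. On that basis, a step of similar size and in the same direction is expected here, so that compound 3 is estimated to be weaker than compound 1, with the change a 2.1-fold higher number from compound 1 to compound 3 (0.31 log units; beyond the scatter). The estimated value for compound 3 in this assay is 140000 nM, within a range from 50000 nM to 400000 nM, with a real chance that only a limit is reported.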

Compound 3, half-maximal inhibitory concentration: 16500 nM
The estimate for compound 3 lay 8.5-fold (0.93 log units) above the measured number; the whole stated range lies above it.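

In this assay, among the compounds shown here, 2-hydroxy-5-methylphenyl in place of 4-bromophenyl gives a 4.1-fold lower number from compound 1 to compound 3 (0.62 log units; beyond the scatter), so a new substituted phenyl at this place does not have to weaken the compound, as the single earlier step might have suggested. Both compound 2 and compound 3 carry oxygen on the phenyl ring, yet the change from 2,4-dimethoxyphenyl to 2-hydroxy-5-methylphenyl gives an at least 10-fold lower number from compound 2 to compound 3 (1.00 log units; beyond the scatter), so the presence of oxygen on the ring does not settle the result in these compounds, and the particular groups matter. The result for compound 2 is a limit and not a number, so the true size of that second step stays unknown: the limit of > 166000 nM in this assay, at which 1 of the 3 values shown sits.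

Compound 3 differs from compound 1 in more than one feature of the phenyl ring, with a hydroxy group and a methyl group both entering as the bromine leaves, so these compounds cannot show which of the two goes with the lower number. Also open, on these data alone, is how the number would respond to a phenyl ring bearing only a hydroxy group, to an amine or a carboxylic acid on the ring, or to a longer chain leading to the ring.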